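Thiocarbonyl amine exchange in the benzamide series

This account rests on a few compounds, and the source may have more. Where it says the series, first, only, none or still open, it means among the compounds named here.

Two members of the series have been measured in a functional assay on MGC-803 cells (Homo sapiens) for antiproliferative activity, read by CCK-8 assay, with a stated time of 72 h, tested at 2 uM; a lower number here means a weaker effect, a higher number a stronger effect of the compound at the concentration tested. Compound 1 `Nc1ccccc1NC(=O)c1ccc(CSC(=S)N2CCc3cc(Cl)ccc32)cc1` gives 57.7%. Compound 2 `CC1CCN(C(=S)SCc2ccc(C(=O)Nc3ccccc3N)cc2)CC1` gives 28.1%, the lowest of the two numbers. For the measured compounds named here, the only measured step, a number 29.6 percentage points lower from compound 1 to compound 2 (beyond the scatter), concerns the same place that is varied next, and it shows that the amine on the thiocarbonyl carbon can move the read-out beyond the scatter. Compound 3 `Nc1ccccc1NC(=O)c1ccc(CSC(=S)N2CCCC2)cc1` carries the change (pyrrolidin-1-yl in place of 4-methylpiperidin-1-yl on a thiocarbonyl carbon). Unlike the measured step, this exchange keeps a non-aromatic ring with one hetero atom at that place and only shrinks it; the data hold no step between two such rings, so no direction can be read from them. The expected step is a number 3.1 percentage points lower from compound 2 to compound 3 (within the scatter), within the scatter. Compound 3 is estimated at 25%, with a range from 10% to 45%.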

Compound 3, a percentage reported as inhibition, at one concentration (the size of the read-out at that concentration, not a potency): 27%
Estimate against measurement, compound 3: 2 percentage points below, within the range that was stated.
By their numbers in this assay, from the lowest: compounds 3 and 2 (each within the scatter of the next); then compound 1.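

In this assay, for the compounds shown here, pyrrolidin-1-yl and 4-methylpiperidin-1-yl on the thiocarbonyl carbon give a number 1.1 percentage points lower from compound 2 to compound 3 (within the scatter) and so cannot be told apart, which is the first comparison of two non-aromatic rings at this place. The second such ring also separates from the 5-chloro-2,3-dihydro-1H-indol-1-yl group, with a number 30.7 percentage points lower from compound 1 to compound 3 (beyond the scatter) as the step, so compound 1 now stands apart from two ring amines rather than one. No accompanying measurement offers an explanation for these numbers.

The compounds shown leave open whether the level of compound 1 depends on the chlorine, a question for the 2,3-dihydro-1H-indol-1-yl group without it. They also leave open whether an open-chain diethylamino group or a morpholin-4-yl ring at this place would read like compound 2 and compound 3.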